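Bromo for fluoro on a weakly active isoxazolidine series

The source may report more compounds than this note shows. Statements on the series, on what has been measured and on what is new or still open speak of the compounds shown alone.

Compound 1 `CCO[C@H]1C[C@@H](c2coc3ccc(F)cc3c2=O)N(c2ccccc2)O1`: 31700 nM
Compound 2 `O=c1c([C@@H]2C[C@H](c3ccccc3)ON2c2ccccc2)coc2ccc(F)cc12`: 49000 nM
Compound 3 `COC(=O)[C@H]1C[C@@H](c2coc3ccc(Cl)cc3c2=O)N(c2ccccc2)O1`: > 60000 nM

Of the compounds shown here, three sharing one core have been measured in a functional assay on PC-3 cells (Homo sapiens) for inhibition, read by sulforhodamine B assay, with a stated time of 48 h; a higher number here means a weaker inhibitor, a lower number a stronger inhibitor. Compound 1 gives 31700 nM and stands as the lowest of the two numbers recorded; its nearest neighbour is compound 2, which gives 49000 nM. The step of a 1.5-fold higher number from compound 1 to compound 2 (0.19 log units; within the scatter) comes with a phenyl in place of ethoxy on a saturated ring carbon, and it lies within the scatter. Compound 3 reports only a limit of the assay, > 60000 nM, at which one of the three values sits (the limit of > 60000 nM in this assay, at which 1 of the 3 values shown sits).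

The unmeasured compound 4 `CCO[C@H]1C[C@@H](c2coc3ccc(Br)cc3c2=O)N(c2ccccc2)O1` differs from compound 1 in one place: bromo in place of fluoro on an aromatic carbon. Within the data shown here, no measured pair isolates a change of halogen on this aromatic carbon, so the one step on record, which lies within the scatter, gives no direction to carry over. Compound 3 carries chloro but changes the side group as well, and its limit cannot be read as a number.

Compound 4 is therefore expected to sit close to compound 1, with the step of a 1.1-fold lower number from compound 1 to compound 4 (0.02 log units; within the scatter) not beyond the scatter. The estimate for compound 4 is 30000 nM, with a range from 10000 nM to 90000 nM.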

Compound 4, half-maximal inhibitory concentration: > 60000 nM
Compound 4 ended at the assay's limit; the forecaster's own chance of this, stated with the estimate: 25%; at least 2.0-fold (0.30 log units) between middle value and limit.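

In this assay, among these compounds, the pair of compound 1 and compound 4 is the first to isolate a change of halogen on this aromatic carbon, and the step is an at least 1.8-fold higher number from compound 1 to compound 4 (0.27 log units; that floor lies within the scatter). This gives the change a direction, since bromo in place of fluoro brings no lower number at this position, but it fixes no size, and the floor of the step does not clear the usual scatter of the assay. Compound 4 reports a limit of the assay rather than a number, and it is the second compound shown to do so: the limit of > 60000 nM in this assay, at which 2 of the 4 values shown sit.

The compounds shown leave open how far beyond that limit compound 4 truly lies, and whether bromo would act in the same way on the core of compound 2, where a phenyl stands in place of the ethoxy. They also leave open what chloro, methoxy or a plain hydrogen on this aromatic carbon would give with the ethoxy group kept, which would show whether fluoro itself matters here or only the absence of bromo.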